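Cyclic keto-sulfonamides on KB cells: a methyl addition

The source may hold more compounds than are shown below. What is called first, only, known or untested is meant among the compounds shown, and "the series" means these compounds.

Measured compounds and their values in a functional assay on KB cells (Homo sapiens) for antiproliferative activity, read by sulforhodamine B assay, tested at 100 ug/mL; on this read-out lower numbers stand for less inhibition and higher numbers for more inhibition at the one concentration tested (going by the name of the read-out):
- compound 1, `Cc1ccc(NS(=O)(=O)C2CCCCC2=O)cc1`: -22.2%
- compound 2, `Cc1cccc(NS(=O)(=O)C2CCCCC2=O)c1C`: -20.6%
- compound 3, `Cc1cccc(S(=O)(=O)C2CCCCCC2=O)c1C`: 2.01%

Compound 1 gives the lowest of the three numbers in this assay. Its nearest neighbour is compound 2, whose value lies within the usual scatter of it, so the two cannot be told apart on this read-out. The furthest is compound 3, which lies beyond the scatter above compound 1; compound 3 differs from the others in more than one place, so nothing can be said about which change carries that gap.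

The next compound is compound 4, `Cc1ccc(NS(=O)(=O)C2CCCCC2=O)c(C)c1`, not yet measured in this assay. It differs from compound 1 by methyl in place of hydrogen on an aromatic carbon, on an aromatic carbon of a six-membered aromatic ring of carbon only, ortho to a large group and meta to a methyl group.

For the measured compounds named here, no step between measured compounds isolates this change. Going by the values given here, compound 2 carries an extra methyl on the same aromatic ring as compound 1 and sits within the scatter of it, which is the only related evidence. For compound 4 a step of a number 4.2 percentage points higher from compound 1 to compound 4 (within the scatter) in this assay is expected, that is, none beyond the scatter. Compound 4 is thus estimated at -18%, within -40% to 5%.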

Compound 4, a percentage reported as inhibition, at one concentration (the size of the read-out at that concentration, not a potency): 7.97%
For compound 4 the middle estimate is 26 percentage points below the measured one, outside the stated range (above it).
By their numbers in this assay, from the lowest: compounds 1 and 2 (each within the scatter of the next); then compounds 3 and 4 (each within the scatter of the next).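

In this assay, for the compounds shown here, methyl in place of hydrogen on an aromatic carbon, ortho to a large group and meta to a methyl group, gives a number 30.2 percentage points higher from compound 1 to compound 4 (beyond the scatter), the first step that isolates a single change. Going by these compounds alone, this shows that the read-out responds to this one position: a single added methyl is enough to carry the value beyond the scatter, which the earlier compounds could not show because none of them differed from another in only one place. No measurement of any property of these compounds bears on this step, so its origin stays unexplained.

As far as these compounds go, whether the step belongs to methyl itself or would also appear with another group at this position, such as a methoxy group, a chlorine atom or an amine, remains open. Also open, from the compounds shown here alone, are whether the same methyl gives a step of this size without the methyl group already on the ring, and what the step means for potency, given that this assay reports only one concentration.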